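Lipophilicity notes on a thiosemicarbazone ether series

This account rests on a few compounds, and the source may have more. Where it says the series, first, only, none or still open, it means among the compounds named here.

Measured compounds:
compound 1, `S=C(N/N=C/c1ccc(Oc2ccccc2)cc1)Nc1ccc(Br)cc1`: 6.38
compound 2, `S=C(N/N=C/c1ccc(Oc2ccc3ccccc3c2)cc1)Nc1ccccc1`: 6.07
compound 3, `Fc1ccc(Oc2ccc(/C=N/NC(=S)Nc3ccc(Br)cc3)cc2)cc1`: 5.82

In a physicochemical assay for lipophilicity, in phosphate buffer, measured as octanol-water partition, with a stated time of 24 h (on this read-out higher numbers stand for higher lipophilicity and lower numbers for lower lipophilicity), compound 3 gives the lowest of the three numbers. Its nearest neighbour is compound 2, which in this assay gives 6.07, a gap that stays within the scatter. Compound 1, which gives 6.38, sits furthest away. For the measured compounds named here, the only measured step that changes one place is a number 0.56 log units lower from compound 1 to compound 3 (beyond the scatter).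

Compound 4, `S=C(N/N=C/c1ccc(Oc2ccc3ccccc3c2)cc1)Nc1ccc(Br)cc1`, is not yet measured in this assay. It differs from compound 3 in one place: naphthalen-2-yl in place of 4-fluorophenyl on an oxygen on an aromatic ring. Going by the values given here, no measured step covers this exchange directly. Compound 2 carries the same naphthalen-2-yl ether as compound 4 but a plain phenyl on the thiourea nitrogen; compound 1 carries the same bromophenyl as compound 4 but a plain phenyl ether. Both pairs differ in two places, so only their two values can be read, and neither gives a step. The step from compound 1 to compound 3 is a different change and bears only indirectly, as a sign that a single ring substituent moves the read-out beyond the scatter.

The expected step is a number 0.78 log units higher from compound 3 to compound 4 (beyond the scatter), upward and beyond the scatter. Compound 4 is estimated at 6.6, with a range from 6.1 to 7.1.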

Compound 4, partition coefficient: 6.93
The estimate for compound 4 lay 0.33 log units below the measured number; low and high end bracket the measured number.
By their numbers in this assay, from the lowest: compounds 3 and 2 (each within the scatter of the next); then compound 1; then compound 4.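

At the aromatic group on the ether oxygen, with the bromophenyl held fixed, this assay gives a number 1.11 log units higher from compound 3 to compound 4 (beyond the scatter) for naphthalen-2-yl in place of 4-fluorophenyl and a number 0.55 log units higher from compound 1 to compound 4 (beyond the scatter) for naphthalen-2-yl in place of phenyl, so the exchange raises the number against both smaller groups in the two pairs at hand. With the naphthalen-2-yl ether held fixed, the series also gains a first measured bromo exchange, a number 0.86 log units higher from compound 2 to compound 4 (beyond the scatter), which leaves compound 4 highest of the four, with its steps to all the others beyond the scatter. No measurement in hand accounts for the size or direction of these steps.

The compounds shown do not tell whether the naphthalen-2-yl exchange gives a similar step with a plain phenyl on the thiourea nitrogen, or whether the bromo exchange gives a similar step with a phenyl ether. From the compounds shown here alone, how a carboxylic acid or an amine on the aromatic ring of the ether would read in this assay also remains open.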